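Chloro in place of fluoro: compound 2 to compound 3

The source may hold more compounds than are shown below. What is called first, only, known or untested is meant among the compounds shown, and "the series" means these compounds.

In a functional assay on THP-1 cells (Homo sapiens) for inhibition (a higher number here means a weaker inhibitor, a lower number a stronger inhibitor), compound 2 (`Fc1ccc(-c2nnnn2Cc2cccnc2)c(Cl)c1Cl`) gives 398 nM and stands within the scatter of compound 1 (`Cc1nc(C)c(Cn2nnnc2-c2cccc(Cl)c2Cl)s1`) at 251 nM on the same read-out. Compound 3 (`Clc1ccc(-c2nnnn2Cc2cccnc2)c(Cl)c1Cl`) carries chloro in place of fluoro on an aromatic carbon and is otherwise the same as compound 2. Within the data shown here, no measured pair shows this change. A small move to a lower number in this assay is expected, hardly beyond the scatter. The estimated step is a 1.6-fold lower number from compound 2 to compound 3 (0.20 log units; within the scatter) as a working figure. For compound 3 the estimate is 250 nM with an expected range of 100 nM to 630 nM for repeat measurements.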

Compound 3, half-maximal inhibitory concentration: 1350 nM
Compound 3: middle estimate off by 5.4-fold (0.73 log units), on the low side; measured number outside the range, above it.
By their numbers in this assay, from the lowest: compounds 1 and 2 (each within the scatter of the next); then compound 3.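

On the aromatic carbon ortho to a chloro group and para to a large group, the series is sensitive to the identity of the halogen: chloro in place of fluoro gives a 3.4-fold higher number from compound 2 to compound 3 (0.53 log units; beyond the scatter) in this assay. The step is beyond the scatter, although the change swaps one heavy atom for one heavy atom and leaves the counted donors, acceptors and charge unchanged, so fluoro is the better of these two halogens here. No supporting data bear on the origin of this step.

As far as these compounds go, how hydrogen, methyl, methoxy or a nitrile on this carbon would compare with fluoro remains open. Also open, from the compounds shown here alone, is whether the same change gives a similar step when the pyridine-bearing side of compound 2 is replaced.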